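Chloro in place of nitro: expectation for compound 3

A few compounds are considered here, and "the series" means these few. Any claim that something is new, unique, unknown or untested is made for them only; others in the source may bear on it.

Within the data shown here, compound 2 `COc1ccc(C(Nc2ccc([N+](=O)[O-])cc2)n2c(=O)ccc3cc(O)ccc32)cc1` carries the smaller of the two numbers so far, although its gap to compound 1 is within the scatter. In a functional assay on MCF7 cells (Homo sapiens) for inhibition, read by MTT assay (on this read-out lower numbers stand for stronger inhibition and higher numbers for weaker inhibition), compound 2 gives 21100 nM. Compound 1 `COc1ccc(C(Nc2ccccc2)n2c(=O)ccc3cc(O)ccc32)cc1` gives 35100 nM. Among the measured compounds shown here, the one measured step reads a 1.7-fold lower number from compound 1 to compound 2 (0.22 log units; within the scatter). Compound 3 `COc1ccc(C(Nc2ccc(Cl)cc2)n2c(=O)ccc3cc(O)ccc32)cc1` differs from compound 2 by chloro in place of nitro on an aromatic carbon. For the measured compounds named here, no measured step covers chloro against nitro; the only step, nitro for hydrogen, stayed within the scatter, so nothing beyond the scatter is expected for compound 3 in this assay. The expected step is a 1.2-fold higher number from compound 2 to compound 3 (0.07 log units; within the scatter). Compound 3 is estimated at 25000 nM, between 8000 nM and 75000 nM.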

Compound 3, half-maximal inhibitory concentration: 11300 nM
Compound 3: middle estimate off by 2.2-fold (0.34 log units), on the high side, and the stated range covers the measured number.
By their numbers in this assay, from the lowest: compounds 3, 2 and 1 (each within the scatter of the next, the first and the last beyond it).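

Chloro in place of hydrogen on this aromatic carbon, para to a large group, gives the first step beyond the scatter in this assay with a 3.1-fold lower number from compound 1 to compound 3 (0.49 log units; beyond the scatter) and a modest size. Chloro in place of nitro gives a 1.9-fold lower number from compound 2 to compound 3 (0.27 log units; within the scatter) and stays within the scatter, so these two groups are not separated at this place. Nothing available explains either step.

Open, from the compounds shown here alone, is how an amine or a carboxylic acid at this place would compare with chloro. Open too, going by these compounds, is whether the chloro step holds with other groups on the shared core.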